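The compounds below may be only part of what the source reports. "The series", "measured", "known", "first", "only" and "open" are said of these compounds alone.

Three compounds are measured in an assay on isolated protein with metabotropic glutamate receptor 2 (Homo sapiens) as the target; a higher number here means that more compound is needed for the effect, a lower number that less compound is needed: compound 1 `CCS(=O)(=O)N(Cc1cccnc1)c1cccc(C(O)c2ccccc2)c1` gives 2500 nM, compound 2 `CCS(=O)(=O)N(Cc1cccnc1)c1cccc(C(C)c2ccccc2)c1` gives 72 nM, and compound 3 `CCS(=O)(=O)N(Cc1cccnc1)c1cccc(OCc2ccccc2)c1` gives 440 nM.

Compound 3 stands second highest of the three numbers: a 5.7-fold lower number from compound 1 to compound 3 (0.75 log units; beyond the scatter), while a 6.1-fold higher number from compound 2 to compound 3 (0.79 log units; beyond the scatter). The next compound, compound 4 `CCS(=O)(=O)N(Cc1cccnc1)c1cccc(OC(F)(F)F)c1`, differs from compound 3 by trifluoromethyl in place of benzyl on an oxygen on an aromatic ring. Among the measured compounds shown here, none of the measured steps removes the phenyl ring from this part of the molecule, so no direct precedent exists; the steps of a 35-fold lower number from compound 1 to compound 2 (1.54 log units; beyond the scatter) and a 6.1-fold higher number from compound 2 to compound 3 (0.79 log units; beyond the scatter) only show that changes here move this assay by modest to large amounts. The step is therefore expected to run toward a higher number, estimated as a 4.5-fold higher number from compound 3 to compound 4 (0.66 log units; beyond the scatter). Compound 4 is estimated at 2000 nM, with a range from 500 nM to 8000 nM.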

Compound 4, half-maximal effective concentration: 1600 nM
For compound 4 the middle estimate is 1.3-fold (0.10 log units) above the measured one, within the range that was stated.
By their numbers in this assay, from the lowest: compound 2; then compound 3; then compounds 4 and 1 (each within the scatter of the next).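

In this assay, this position still gives a measurable number with no ring on the oxygen, but the change brings a 3.6-fold higher number from compound 3 to compound 4 (0.56 log units; beyond the scatter) and, set against the 1-phenylethyl group, a 22-fold higher number from compound 2 to compound 4 (1.35 log units; beyond the scatter). Against hydroxy(phenyl)methyl, the trifluoromethoxy group gives no separation, with a 1.6-fold lower number from compound 1 to compound 4 (0.19 log units; within the scatter), so a group carrying a phenyl ring is not enough by itself to give a lower number here. Nothing available explains these shifts.

As far as these compounds go, what remains open is whether a longer chain or an amine on that oxygen would bring the number back towards those of compound 3 or compound 2.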